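One ring swapped: from compound 3 to compound 4

The source may report more compounds than this note shows. Statements on the series, on what has been measured and on what is new or still open speak of the compounds shown alone.

Compound 1 `OC(c1ccc(Br)cc1)(c1ccc(C(F)(F)F)cc1)c1cccnc1`: 54700 nM
Compound 2 `CC(C)c1ccc(C(O)(c2ccc(C(F)(F)F)cc2)c2cccnc2)cc1`: 56300 nM
Compound 3 `OC(c1ccc(C(F)(F)F)cc1)(c1cccnc1)c1ccc(Cl)cc1F`: > 100000 nM

These values come from an ADME assay on L6 cells (Rattus norvegicus) for cytotoxicity, read by resazurin assay, with a stated time of 72 h; a lower number here means a stronger inhibitor, a higher number a weaker inhibitor. Compound 3 gives only a limit of the assay, > 100000 nM, not a number. This is the only such case among the three: the limit of > 100000 nM in this assay, at which 1 of the 3 values shown sits. The steps that reach it give only floors: an at least 1.8-fold higher number from compound 1 to compound 3 (0.26 log units; that floor lies within the scatter), and an at least 1.7-fold higher number from compound 2 to compound 3 (0.24 log units; that floor lies within the scatter).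

Compound 4 `OC(c1ccc(C(F)(F)F)cc1)(c1cccnc1)c1cc2ccccc2s1` has not yet been measured. It keeps the shared core and changes one group: 1-benzothiophen-2-yl in place of 4-chloro-2-fluorophenyl on a saturated chain carbon bound to two aromatic carbons and an oxygen on a saturated carbon.

Within the data shown here, no measured compound carries the new group, so the closest guides are the other changes to this aryl group. Besides the two floors, there is a 1.0-fold higher number from compound 1 to compound 2 (0.01 log units; within the scatter). None of these steps goes beyond the scatter, so no large effect is expected, and compound 4 should probably land near compound 1 and compound 2 in this assay. The expected step is an at least 2.0-fold lower number from compound 3 to compound 4 (0.30 log units; that floor lies within the scatter). For compound 4 the estimated value is 50000 nM, with an expected range from 20000 nM to 100000 nM.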

Compound 4, half-maximal inhibitory concentration: 58700 nM
Beside the measured number, compound 4's estimate is 1.2-fold (0.07 log units) below it; low and high end bracket the measured number.
By their numbers in this assay, from the lowest: compounds 1, 2 and 4 (each within the scatter of the next). At a limit, above all of these: compound 3.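

In this assay, the two-ring 1-benzothiophen-2-yl group on this carbon gives a result within the scatter of the 4-bromophenyl and 4-isopropylphenyl groups: a 1.1-fold higher number from compound 1 to compound 4 (0.03 log units; within the scatter), and a 1.0-fold higher number from compound 2 to compound 4 (0.02 log units; within the scatter). So, among these compounds, this position accepts a five-membered aromatic ring with a sulfur atom, fused to a six-membered ring, with no step beyond the scatter. The comparison with the 4-chloro-2-fluorophenyl group gives only a floor, an at least 1.7-fold lower number from compound 3 to compound 4 (0.23 log units; that floor lies within the scatter), and compound 3 remains the one compound at a limit rather than a number: the limit of > 100000 nM in this assay, at which 1 of the 4 values shown sits.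

The compounds shown leave open whether an amine or a carboxylic acid on this carbon, in place of the aromatic group, would give a number outside the scatter of these values. From the compounds shown here alone, how far compound 3 truly lies from the others also stays unknown.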